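Urea analogues tested against a pain-sensing ion channel

This account rests on a few compounds, and the source may have more. Where it says the series, first, only, none or still open, it means among the compounds named here.

Compound 1 `O=C(Nc1ccc(C(F)(F)F)cc1)N1CCN(c2ccc(-c3ccccc3)nn2)CC1` was tested in an assay on HEK293 cells for inhibition of transient receptor potential cation channel subfamily V member 1 (Homo sapiens), read by FLIPR, at pH 5.5; on this read-out lower numbers stand for stronger inhibition and higher numbers for weaker inhibition. For compound 1 the result is only a limit of the assay, > 10000 nM. Compound 2 `O=C(Nc1ccc(OC(F)(F)F)cc1)N1CCN(c2ccc(-c3ccccc3)nn2)CC1` differs from compound 1 by trifluoromethoxy in place of trifluoromethyl on an aromatic carbon. For compound 2 the result is likewise a limit, > 10000 nM. Between them lies a step that the two limits leave unreadable from compound 1 to compound 2. Compound 3 `O=C(Nc1ccc(C(F)(F)F)cc1)N1CCN(c2nncc3ccccc23)CC1` carries another core, and the difference between the two cores is not broken down here. For compound 3 the result is again a limit, > 10000 nM. All three values share (the limit of > 10000 nM in this assay, at which 3 of the 3 values shown sit). Compound 4 `O=C(Nc1ccc(OC(F)(F)F)cc1)N1CCN(c2nncc3ccccc23)CC1` differs from compound 3 by trifluoromethoxy in place of trifluoromethyl on an aromatic carbon, the same kind of change with the same place as before. The step from compound 3 to compound 4 in this assay is expected to be a step that the limit leaves unreadable from compound 3 to compound 4, beside the earlier unreadable one, because compound 3 already stands at the limit of > 10000 nM in this assay, at which 3 of the 3 values shown sit. Compound 4 is expected to give 20000 nM in this assay, with a likely range from 8000 nM to 60000 nM.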

Compound 4, half-maximal inhibitory concentration: > 10000 nM
Compound 4 ended at the assay's limit; the forecaster's own chance of this, stated with the estimate: 85%; the middle value does not contradict the limit.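

No step can be read from compound 3 to compound 4, because both results in this assay are limits: the limit of > 10000 nM in this assay, at which 4 of the 4 values shown sit.

The compounds shown leave open how far either group or either core shifts inhibition in this assay once a result falls inside the assay's range.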